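A few compounds are considered here, and "the series" means these few. Any claim that something is new, unique, unknown or untested is made for them only; others in the source may bear on it.

Measured so far:
compound 1 `COc1ccc(/C=C\c2cc(OC)c(OC)c(OC)c2)cc1OCc1ccc(CN2C[C@H](O)C[C@@H]2C(=O)O)cc1` — in a functional assay on HeLa cells (Homo sapiens) for antiproliferative activity, read by CCK-8 assay, with a stated time of 48 h (on this read-out higher numbers stand for weaker inhibition and lower numbers for stronger inhibition), compound 1 gives > 10000 nM, a limit of the assay rather than a number.
compound 2 `COc1ccc(/C=C\c2cc(OC)c(OC)c(OC)c2)cc1OCc1ccc(CN2CCCCC2C(=O)O)cc1` — in this assay compound 2 gives 14200 nM.

Compound 2 holds the only number shown; the other value is the limit (the limit of > 10000 nM in this assay, at which 1 of the 2 values shown sits). The single step shown, a step that the limit leaves unreadable from compound 1 to compound 2, is therefore unreadable in size and concerns a different exchange.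

Compound 3 `COc1ccc(/C=C\c2cc(OC)c(OC)c(OC)c2)cc1OCc1ccc(CNCCNC(C)=O)cc1` is not yet measured. Against compound 2 it carries (2-acetamidoethyl)amino in place of 2-carboxypiperidin-1-yl on a saturated chain carbon bound to an aromatic carbon. Within the data shown here, no measured step bears on this change, so the expectation rests on compound 2 alone, anchored at 14200 nM, and a step beyond the scatter is not expected in this assay.

Compound 3 is expected to give about 9000 nM in this assay, between 2500 nM and 30000 nM. The expected step is a 1.6-fold lower number from compound 2 to compound 3 (0.20 log units; within the scatter), within the scatter.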

Compound 3, half-maximal inhibitory concentration: 6400 nM
Beside the measured number, compound 3's estimate is 1.4-fold (0.15 log units) above it; low and high end bracket the measured number.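

In this assay, the place on a saturated chain carbon bound to an aromatic carbon now has its first readable step, a 2.2-fold lower number from compound 2 to compound 3 (0.35 log units; beyond the scatter). An open chain with no ring, (2-acetamidoethyl)amino, therefore gives a lower number here than 2-carboxypiperidin-1-yl, so neither the six-membered ring nor the carboxy group is required for activity at this level. Compound 1 sits at a limit, so its step to compound 2 cannot be read and an at least 1.5-fold lower number from compound 1 to compound 3 (0.19 log units; that floor lies within the scatter) is only a floor: the limit of > 10000 nM in this assay, at which 1 of the 3 values shown sits.

On these data alone, the exchange removes the ring and the carboxy group together and brings in the acetamide, so the share of each in the step remains open. A plain (2-aminoethyl)amino group, a longer chain ending in the same acetamide, or an open-chain carboxylic acid at this place would separate these parts.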